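The compounds below may be only part of what the source reports. "The series", "measured", "known", "first", "only" and "open" are said of these compounds alone.

Working notes on the series. One core is shared by compound 1 `CCC1(Cc2ccccc2)OS(=O)(=O)C=C1OCc1ccc(Cl)cc1`, compound 2 `CCC1(Cc2ccccc2)OS(=O)(=O)C=C1OCC#N` and compound 3 `CCC1(Cc2ccccc2)OS(=O)(=O)C=C1OCCCc1ccccc1`. In an ADME assay on HEL cells (Homo sapiens) for cytotoxicity, with a stated time of 3 days (on this read-out higher numbers stand for lower toxicity in this test and lower numbers for higher toxicity in this test), compound 2 gives > 400000 nM, which is a limit of the assay and not a number. Compound 1 gives >= 50000 nM in this assay, again a limit. Compound 3 gives >= 20000 nM in this assay, also a limit. Because every value shown sits at a limit of > 400000 nM in this assay, at which 1 of the 3 values shown sits, the limit of >= 20000 nM in this assay, at which 1 of the 3 values shown sits (the limit of >= 50000 nM in this assay, at which 1 of the 3 values shown sits), none of the steps among the measured compounds can be read: a step that the two limits leave unreadable from compound 1 to compound 2, a step that the two limits leave unreadable from compound 1 to compound 3 and a step that the two limits leave unreadable from compound 2 to compound 3 all remain of unknown size. Compound 4 `CCC1(Cc2ccccc2)OS(=O)(=O)C=C1NCc1ccccc1` has not yet been measured; it differs from compound 2 by benzylamino in place of cyanomethoxy on a double-bonded ring carbon. For the measured compounds named here, no measured step touches this exchange, and the three measured steps give no readable size for any change. Going by the values given here, the only guide is that every measured compound sits at a limit in this assay. Compound 4 is accordingly expected to show no change beyond the scatter, an expected step of an at least 4.0-fold lower number from compound 2 to compound 4 (0.60 log units; beyond the scatter). The estimate for compound 4 in this assay is 100000 nM, with an expected range from 20000 nM to 400000 nM.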

Compound 4, minimum cytotoxic concentration: >= 80000 nM
Compound 4 was reported as a limit (the forecaster's own chance of this, stated with the estimate: 80%); the middle value does not contradict the limit.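

Compound 2 and compound 4 both stand at limits in this assay, and the step between them cannot be read. The compounds shown leave open whether benzylamino in place of cyanomethoxy changes this read-out at all, and how far compound 1, compound 2, compound 3 and compound 4 differ.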